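Ester groups that leave toxicity level

A few compounds are considered here, and "the series" means these few. Any claim that something is new, unique, unknown or untested is made for them only; others in the source may bear on it.

In an ADME assay on RAW264.7 cells (Mus musculus) for cytotoxicity, read by MTT assay, with a stated time of 24 h (on this read-out higher numbers stand for lower toxicity in this test and lower numbers for higher toxicity in this test), compound 1 `CC/C=C\C[C@H]1C(=O)C=C[C@H]1CC(=O)Oc1ccccc1` gives 158 uM and compound 2 `CC/C=C\C[C@H]1C(=O)C=C[C@H]1CC(=O)OCCO` gives 161 uM while compound 3 `CC/C=C\C[C@H]1C(=O)C=C[C@H]1CC(=O)OCCOCCOC` gives 161 uM and so stands level with compound 2 and within the scatter of compound 1. Compound 4 `CC/C=C\C[C@H]1C(=O)C=C[C@H]1CC(=O)OC(C)CC` carries sec-butyl in place of 2-(2-methoxyethoxy)ethyl on an oxygen next to a carbonyl group. The measured steps that bear on this change show a 1.0-fold higher number from compound 1 to compound 2 (0.01 log units; within the scatter) and a 1.0-fold higher number from compound 1 to compound 3 (0.01 log units; within the scatter) and no change at the digits printed from compound 2 to compound 3 (within the scatter) with none beyond the scatter. None of these compounds carries sec-butyl, so the expectation remains uncertain. The estimated step is a 1.1-fold lower number from compound 3 to compound 4 (0.03 log units; within the scatter) and is expected to stay within the scatter in this assay once measured. Compound 4 is estimated at 150 uM within an expected range of 90 uM to 240 uM in this series.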

Compound 4, half-maximal toxic concentration: 53 uM
For compound 4 the middle estimate is 2.8-fold (0.45 log units) above the measured one; measured number outside the range, below it.
By their numbers in this assay, from the lowest: compound 4; then compounds 1, 2 and 3 (each within the scatter of the next).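

At this place, on an oxygen next to a carbonyl group, the group carried can change the outcome in this assay: sec-butyl gives a 3.0-fold lower number from compound 3 to compound 4 (0.48 log units; beyond the scatter) and a 3.0-fold lower number from compound 2 to compound 4 (0.48 log units; beyond the scatter) and a 3.0-fold lower number from compound 1 to compound 4 (0.47 log units; beyond the scatter). Phenyl, 2-hydroxyethyl and 2-(2-methoxyethoxy)ethyl had stayed within the scatter of one another, so this is the first sign that the position is not indifferent to its ester group. Nothing available explains why sec-butyl parts from the other three. Going by these compounds, whether n-butyl or tert-butyl on that oxygen would follow sec-butyl or stay with the other three remains open.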